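A few compounds are considered here, and "the series" means these few. Any claim that something is new, unique, unknown or untested is made for them only; others in the source may bear on it.

Compound 2 `CCN(CC)c1nc2nc(C)c(CN)c(-c3ccc(Cl)cc3Cl)n2n1` gives in an assay on isolated protein for inhibition of Dipeptidyl peptidase 9 (Homo sapiens) (on this read-out higher numbers stand for weaker inhibition and lower numbers for stronger inhibition), a value of > 30000 nM, which is a limit of the assay rather than a number. Compound 1 `Cc1nc2nc(C)c(CN)c(-c3ccc(Cl)cc3Cl)n2n1` gives in this assay > 30000 nM, likewise a limit. The step that the two limits leave unreadable from compound 1 to compound 2 is therefore unreadable, and the limit of > 30000 nM in this assay, at which 2 of the 2 values shown sit, is all the evidence the two measured compounds offer. Compound 3 `Cc1nc2nc(C(=O)Nc3ccccc3)nn2c(-c2ccc(Cl)cc2Cl)c1CN` differs from compound 2 by phenylcarbamoyl in place of diethylamino on an aromatic carbon. Among the compounds with values here, no measured step bears on this change, so the data give no size or direction to expect in this assay. Compound 3 is nonetheless estimated at 20000 nM, within 3000 nM to 60000 nM, which means an expected step of an at least 1.5-fold lower number from compound 2 to compound 3 (0.17 log units; that floor lies within the scatter).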

Compound 3, inhibition constant: > 10000 nM
Compound 3 gave a limit, no number; the forecaster's own chance of this, stated with the estimate: 55%; the middle value is on the limit's open side.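

Within the data shown here, compound 1, compound 2 and compound 3 all gave limits of the assay rather than numbers, so no step among them can be read. In this assay the compounds shown leave open whether methyl, diethylamino and phenylcarbamoyl differ at all.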